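The source may report more compounds than this note shows. Statements on the series, on what has been measured and on what is new or still open speak of the compounds shown alone.

Working notes on the series.

Compound 1 `Cc1ccccc1-c1ccc(NC[C@H]2CC[C@]3(CC2)CN(c2cccnn2)C(=O)O3)nn1` was characterised in an ADME assay on brain (Rattus norvegicus) for protein binding (a higher number here means a larger unbound share of the compound, a lower number a smaller unbound share), and gives 0.051. Two further members of the series share its core. Compound 2 `O=C1O[C@]2(CC[C@H](CNc3ccn(-c4ccccc4F)n3)CC2)CN1c1ccccn1` was run in this assay but has no number: for compound 2 the outcome stands as "not determined" (no result reported). Compound 3 `O=C1O[C@]2(CC[C@H](CNc3cnn(-c4ccccc4F)c3)CC2)CN1c1ccnnc1` gives 0.044 in this assay. The values of compound 1 and compound 3 lie within the usual scatter of each other, so no order between the two can be read from these figures, and compound 1 is simply one of two compounds of the series with a number in this assay.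

The next compound, compound 4 `O=C1O[C@]2(CC[C@H](CNc3ccc(-c4cc(F)cc(F)c4)nn3)CC2)CN1c1cccnn1`, has not yet been measured. Its structure differs from compound 1 in one place: 3,5-difluorophenyl in place of 2-methylphenyl on an aromatic carbon

Among the compounds with values here, no pair of measured compounds differing in a single place is available, so the size of this kind of change in this assay cannot be taken from the series itself. The two numbers in hand, from compound 1 and compound 3, sit close together across a different variation of the same core. On that basis a step from compound 1 to compound 4 of a 1.0-fold lower number from compound 1 to compound 4 (0.01 log units; within the scatter) is expected, that is, none beyond the scatter. For compound 4 the expected unbound fraction in this assay is 0.05, with a range from 0.028 to 0.09.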

Compound 4, unbound fraction: 0.016
The estimate for compound 4 lay 3.1-fold (0.49 log units) above the measured number, outside the stated range (below it).
By their numbers in this assay, from the lowest: compound 4; then compounds 3 and 1 (each within the scatter of the next).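

In this assay, the replacement of 2-methylphenyl by 3,5-difluorophenyl on this aromatic carbon gives a 3.2-fold lower number from compound 1 to compound 4 (0.50 log units; beyond the scatter), the first single-place step available in the series, and it shows that this position is not neutral for the read-out. The step appears although the leaving and entering groups share much of what is counted: each is one six-membered aromatic ring of carbon only, with no hydrogen-bond donors or acceptors and no net charge, while the heavy atoms go from 7 to 8 and the composition changes from all carbon to 6 carbon and 2 fluorine. No measurement in hand accounts for the step.

From the compounds shown here alone, it remains open whether the step goes with the loss of the methyl group, the arrival of the fluorines, or the two together, since this one pair cannot separate them. Also open, going by these compounds, is how the unbound fraction would respond at this position to an unsubstituted phenyl, or to a phenyl carrying an amine or a carboxylic acid.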